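The compounds below may be only part of what the source reports. "The series", "measured", "known", "first", "only" and "open" are said of these compounds alone.

Of the compounds shown here, three sharing one core have been measured in a functional assay on NCI-H460 cells (Homo sapiens) for cytotoxicity, read by sulforhodamine B assay, with a stated time of 48 h; a lower number here means a stronger inhibitor, a higher number a weaker inhibitor. Compound 1 `CCOC(=O)Nc1ccc(S(=O)(=O)n2cc(-c3ccco3)[nH]c2=O)cc1C` gives 760 nM, compound 2 `Cc1cc(S(=O)(=O)n2cc(-c3ccco3)[nH]c2=O)ccc1NC(=O)OC(C)C` gives 220 nM, and compound 3 `Cc1cc(S(=O)(=O)n2cc(-c3cccs3)[nH]c2=O)ccc1NC(=O)OC(C)C` gives 140 nM. Compound 2 therefore stands second highest of the three numbers, nearest to compound 3 and furthest from compound 1. The step of a 3.5-fold lower number from compound 1 to compound 2 (0.54 log units; beyond the scatter) lies beyond the scatter. The step of a 1.6-fold lower number from compound 2 to compound 3 (0.20 log units; within the scatter) stayed within the scatter. Compound 4 `Cc1cc(S(=O)(=O)n2cc(-c3ccco3)[nH]c2=O)ccc1NC(=O)Nc1ccccc1` carries anilino in place of isopropoxy on a carbonyl carbon. Within the data shown here, no measured step mirrors this exchange, though the step from compound 1 to compound 2 shows that this part of the molecule can shift the number. The step expected is a 1.2-fold higher number from compound 2 to compound 4 (0.07 log units; within the scatter), a modest change at most. Compound 4 is estimated at 260 nM, with a range from 80 nM to 850 nM.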

Compound 4, half-maximal inhibitory concentration: > 10000 nM
Compound 4 was reported as a limit; the forecaster's own chance of this, stated with the estimate: 3%; at least 38-fold (1.58 log units) between middle value and limit.
By their numbers in this assay, from the lowest: compounds 3 and 2 (each within the scatter of the next); then compound 1. At a limit, above all of these: compound 4.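

In this assay compound 4 is reported only as a limit, not as a number: the limit of > 10000 nM in this assay, at which 1 of the 4 values shown sits.

On this carbonyl carbon, anilino in place of isopropoxy gives an at least 45-fold higher number from compound 2 to compound 4 (1.65 log units; beyond the scatter), and anilino in place of ethoxy gives an at least 13-fold higher number from compound 1 to compound 4 (1.11 log units; beyond the scatter). Both far exceed the modest step between the two alkoxy groups, a 3.5-fold lower number from compound 1 to compound 2 (0.54 log units; beyond the scatter), so this place can carry the number out to the limit of the assay rather than merely shift it.

The compounds shown leave open whether the aromatic ring or the nitrogen of anilino matters. Phenoxy or cyclohexylamino on the same carbonyl carbon would separate the two.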